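The compounds below may be only part of what the source reports. "The series", "measured", "known", "first", "only" and "open" are said of these compounds alone.

Compound 1 `CCC1(Cc2ccccc2)OS(=O)(=O)C=C1OCc1ccc(Cl)cc1` is the reference point of the series. In an ADME assay on HEL cells (Homo sapiens) for cytotoxicity, with a stated time of 3 days (on this read-out higher numbers stand for lower toxicity in this test and lower numbers for higher toxicity in this test), compound 1 gives >= 50000 nM, which is a limit of the assay rather than a number. Compound 2 `CCC1(Cc2ccccc2)OS(=O)(=O)C=C1OCc1ccc(C(F)(F)F)cc1` differs from compound 1 by trifluoromethyl in place of chloro on an aromatic carbon. In this assay compound 2 gives >= 16000 nM, also a limit. The step that the two limits leave unreadable from compound 1 to compound 2 cannot be read, since both values rest at limits, the limit of >= 16000 nM in this assay, at which 1 of the 2 values shown sits, and (the limit of >= 50000 nM in this assay, at which 1 of the 2 values shown sits). Compound 3 `CCC1(Cc2ccccc2)OS(=O)(=O)C=C1OCCc1ccccc1` carries the change benzyl in place of 4-chlorophenyl on a saturated chain carbon bound to an oxygen on an unsaturated carbon relative to compound 1. Among the measured compounds shown here, no measured step bears directly on this exchange, and the one step is unreadable, so the reference limit is the only guide. Compound 3 is expected to remain at or near that limit, with a step of a number no higher from compound 1 to compound 3 (the limit leaves the size open) expected to stay within the scatter. The estimate for compound 3 in this assay is 50000 nM, in the range 20000 nM to 100000 nM.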

Compound 3, minimum cytotoxic concentration: >= 20000 nM
Compound 3 was reported as a limit; the forecaster's own chance of this, stated with the estimate: 80%; the middle value does not contradict the limit.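

Compound 1 and compound 3 both rest at limits in this assay, and the step between them cannot be read. The compounds shown leave open where the actual minimum cytotoxic concentration of each lies, and whether benzyl in place of 4-chlorophenyl changes it at all.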